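Compound 3 to compound 4: methoxycarbonyl to carboxy

The source may report more compounds than this note shows. Statements on the series, on what has been measured and on what is new or still open speak of the compounds shown alone.

Measured so far in a functional assay (trachea) with Cavia porcellus as the target (on this read-out lower numbers stand for stronger inhibition and higher numbers for weaker inhibition), on this series:
- Compound 1 `O=c1c2ccccc2c(-c2cccnc2)nn1Cc1cccc(Cl)c1` gives 4170 nM
- Compound 2 `CC(=O)Cn1nc(-c2cccnc2)c2ccccc2c1=O` gives 40700 nM
- Compound 3 `COC(=O)c1ccc(Cn2nc(-c3cccnc3)c3ccccc3c2=O)cc1` gives 5890 nM

Compound 3 lies within the scatter of compound 1, while compound 2 stands clearly apart from both with the highest number of the three. Compound 4 `O=C(O)c1ccc(Cn2nc(-c3cccnc3)c3ccccc3c2=O)cc1` follows from compound 3 through one change, hydrogen in place of methyl on an oxygen next to a carbonyl group (hydrogen in place of methyl on an oxygen next to a carbonyl group, methoxycarbonyl to carboxy). Among the compounds with values here, no measured step covers this change directly. Within the data shown here, the nearest evidence is a 9.8-fold higher number from compound 1 to compound 2 (0.99 log units; beyond the scatter) (acetyl in place of 3-chlorophenyl), which shows only that a change on the chain carbon can move the number in this assay beyond the scatter. A step toward a higher number is therefore expected, no larger than that one and possibly close to the scatter, though this remains weakly supported. The estimate corresponds to a 2.0-fold higher number from compound 3 to compound 4 (0.31 log units; beyond the scatter) as the expected step. For compound 4 the expected value is 12000 nM in this assay (estimated range 4000 nM to 40000 nM).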

Compound 4, half-maximal inhibitory concentration: 17000 nM
Estimate against measurement, compound 4: 1.4-fold (0.15 log units) below, and the stated range covers the measured number.
By their numbers in this assay, from the lowest: compounds 1 and 3 (each within the scatter of the next); then compound 4; then compound 2.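

In this assay, the swap of methoxycarbonyl to carboxy is the first change shown on the far end of the aryl substituent, and removing this one methyl moves the number beyond the scatter (a 2.9-fold higher number from compound 3 to compound 4 (0.46 log units; beyond the scatter)). Compared with the other chain substituents, 4-carboxyphenyl stays clearly apart from both acetyl (a 2.4-fold lower number from compound 2 to compound 4 (0.38 log units; beyond the scatter)) and 3-chlorophenyl (a 4.1-fold higher number from compound 1 to compound 4 (0.61 log units; beyond the scatter)), so compound 4 occupies a level of its own among the four compounds. No measurement shown here accounts for the size of these steps.

From the compounds shown here alone, whether the higher number follows the free carboxy group specifically or any replacement of methoxycarbonyl stays open, and a primary amide or a hydroxymethyl group in its place would separate the two readings. The carboxy group also appears only as 4-carboxyphenyl, so a 3-carboxyphenyl group remains an open comparison with 3-chlorophenyl.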